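A few compounds are considered here, and "the series" means these few. Any claim that something is new, unique, unknown or untested is made for them only; others in the source may bear on it.

Working notes on the sulfonamide series. Compound 1 `COc1ccccc1S(=O)(=O)Nc1ccc2oc(-c3ccccc3)nc2c1` gives 41000 nM in an ADME assay on HEK293 cells (Homo sapiens) for cytotoxicity, read by resazurin assay, with a stated time of 48 h; on this read-out higher numbers stand for lower toxicity in this test and lower numbers for higher toxicity in this test. Compound 3 `CCc1ccc(S(=O)(=O)Nc2ccc3oc(-c4ccccc4)nc3c2)cc1` carries 4-ethylphenyl in place of 2-methoxyphenyl on a sulfonyl sulfur and gives 81000 nM in this assay; the step is a 2.0-fold higher number from compound 1 to compound 3 (0.30 log units; within the scatter). Compound 2 `COc1ccccc1S(=O)(=O)Nc1ccc(-c2nc3ccccc3o2)cc1` reaches only a limit of the assay in this assay, > 100000 nM. The difference between the cores of compound 1 and compound 2 is not broken down here. Compound 4 `CCc1ccc(S(=O)(=O)Nc2ccc(-c3nc4ccccc4o3)cc2)cc1` is not yet measured in this assay; it carries 4-ethylphenyl in place of 2-methoxyphenyl on a sulfonyl sulfur, the same change at the same place as from compound 1 to compound 3, which occurs twice among these compounds. That earlier step stayed within the scatter, and the parent compound 2 already stands at the limit of > 100000 nM in this assay, at which 1 of the 3 values shown sits. Compound 4 is therefore expected to show a step that the limit leaves unreadable from compound 2 to compound 4. The estimate for compound 4 in this assay is 150000 nM, expected to lie between 70000 nM and 350000 nM.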

Compound 4, half-maximal cytotoxic concentration: 82000 nM
For compound 4 the middle estimate is 1.8-fold (0.26 log units) above the measured one; low and high end bracket the measured number.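

In this assay, 4-ethylphenyl in place of 2-methoxyphenyl on a sulfonyl sulfur gives an at least 1.2-fold lower number from compound 2 to compound 4 (0.08 log units; that floor lies within the scatter). Set beside the earlier step, the change can be compared across the two cores only as far as the limit allows: the same change on two cores in this assay, a 2.0-fold higher number (0.30 log units; within the scatter) from compound 1 to compound 3 and an at least 1.2-fold lower number (0.08 log units; that floor lies within the scatter) from compound 2 to compound 4; the limit leaves it open whether they differ. The notes therefore show neither that the change carries over from one core to the other with the same size nor that it behaves differently, and the value of compound 2 remains a limit rather than a number: the limit of > 100000 nM in this assay, at which 1 of the 4 values shown sits.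

Still open, from the compounds shown here alone, is how an amine or a carboxylic acid in place of 4-ethylphenyl on a sulfonyl sulfur would read in this assay on either core. Also open, going by these compounds, is whether such a group would give a step beyond the scatter.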